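Mirror Image of an Inactive Lactone: What to Expect

This account rests on a few compounds, and the source may have more. Where it says the series, first, only, none or still open, it means among the compounds named here.

Compound 2 `CC(C)(C)OC(=O)CC[C@H]1N=C2C[C@H]3C[C@H](C3(C)C)[C@@]2(C)OC1=O` was tested in an ADME assay on NIH3T3 cells (Mus musculus) for antiproliferative activity, read by sulforhodamine B assay, with a stated time of 48 h; a lower number here means a stronger inhibitor, a higher number a weaker inhibitor. In this assay compound 2 gives > 1200000 nM, which is a limit of the assay and not a number. Compound 1 `CC1(C)[C@H]2CC3=N[C@H](CCC(=O)O)C(=O)O[C@]3(C)[C@@H]1C2` likewise gives > 1200000 nM, a limit. Compound 3 `CC1(C)N=C2C[C@H]3C[C@H](C3(C)C)[C@@]2(C)OC1=O` gives > 2000000 nM, also a limit. Within the data shown here, the only step between measured compounds that differ in one place is a step that the two limits leave unreadable from compound 1 to compound 2, and its size cannot be read. Compound 4 `CC(C)(C)OC(=O)CC[C@@H]1N=C2C[C@@H]3C[C@@H](C3(C)C)[C@]2(C)OC1=O` differs from compound 2 as follows: the two compounds have the same atoms and bonds and differ only in configuration as drawn: 4 of 4 stereo elements differ (all stereocentres are inverted: mirror images); a stereocentre at a saturated ring carbon is drawn R in compound 2 and S in compound 4; a stereocentre at a saturated ring carbon is drawn R in compound 2 and S in compound 4; a stereocentre at a saturated ring carbon is drawn R in compound 2 and S in compound 4; a stereocentre at a saturated ring carbon is drawn R in compound 2 and S in compound 4. Among the measured compounds shown here, no measured step shows how mirror images compare here, and the evidence holds only limits: the limit of > 1200000 nM in this assay, at which 2 of the 3 values shown sit, and (the limit of > 2000000 nM in this assay, at which 1 of the 3 values shown sits). Compound 4 is therefore expected to behave like compound 2, with no step beyond the scatter (a step that the limit leaves unreadable from compound 2 to compound 4), most likely again as a limit. The estimate for compound 4 is 1500000 nM, with a range from 500000 nM to 5000000 nM.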

Compound 4, half-maximal inhibitory concentration: > 1000000 nM
Compound 4 was reported as a limit (the forecaster's own chance of this, stated with the estimate: 85%); the middle value lies beyond the limit too.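

Among these compounds, compound 2 and compound 4 are mirror images, and both are reported only as limits, so no step between them can be read. From the compounds shown here alone, whether mirror-image configuration matters at all in this assay stays open: all the compounds shown sit at limits.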